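The source may hold more compounds than are shown below. What is called first, only, known or untested is meant among the compounds shown, and "the series" means these compounds.

In an ADME assay (liver) for metabolic stability, with Liver microsome (Homo sapiens) as the target, using microsomes and NADPH, with a stated time of 30 min, tested at 1 uM (on this read-out lower numbers stand for slow clearance and higher numbers for fast clearance), compound 1 `CC(C)n1cc(-c2cc(C(O)(C(F)(F)F)C(F)(F)F)cnc2N2CCN(S(=O)(=O)c3ccc(N)nc3)CC2)cn1` gives 38 mL.min-1.g-1. Compound 2 `Nc1ccc(S(=O)(=O)N2CCN(c3ncc(C(O)(C(F)(F)F)C(F)(F)F)cc3-c3ccc4c(c3)CC(=O)N4)CC2)cn1` gives < 14 mL.min-1.g-1, which is a limit and not a number. Its standing in the series is the limit of < 14 mL.min-1.g-1 in this assay, at which 1 of the 2 values shown sits.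

The next analogue, compound 3 `Nc1ccc(S(=O)(=O)N2CCN(c3ncc(C(O)(C(F)(F)F)C(F)(F)F)cc3-c3ccc4[nH]ncc4c3)CC2)cn1`, changes the same aromatic carbon: a group of 9 heavy atoms (7 carbon, 2 nitrogen; one five-membered aromatic ring with 2 hetero atoms, one six-membered aromatic ring of carbon only) in place of a group of 10 heavy atoms (8 carbon, 1 nitrogen, 1 oxygen; one five-membered non-aromatic ring with 1 hetero atom, one six-membered aromatic ring of carbon only), on an aromatic carbon. The group entering compound 3, 1H-indazol-5-yl, has a five-membered aromatic ring with 2 hetero atoms, as does the group in compound 1, and a six-membered aromatic ring of carbon only, as does the group in compound 2.

Among the measured compounds shown here, only one measured step bears on this change: an at least 2.7-fold lower number from compound 1 to compound 2 (0.43 log units; beyond the scatter). It is a single step, and its size is open-ended, so the expectation for compound 3 is loose. With features of both groups present, a value between those of compound 2 and compound 1 is expected, closer to the low end.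

The expected change is small and towards a higher number, near the scatter: an at least 1.2-fold higher number from compound 2 to compound 3 (0.10 log units; that floor lies within the scatter). For compound 3 the estimate in this assay is 18 mL.min-1.g-1, with an expected range of 8 mL.min-1.g-1 to 38 mL.min-1.g-1.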

Compound 3, intrinsic clearance in microsomes: 27 mL.min-1.g-1
Compound 3: middle estimate off by 1.5-fold (0.18 log units), on the low side; measured number inside the range.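

At this aromatic carbon, the 1H-indazol-5-yl group of compound 3 and the 1-isopropyl-1H-pyrazol-4-yl group of compound 1 cannot be told apart in this assay, with a 1.4-fold lower number from compound 1 to compound 3 (0.15 log units; within the scatter). On the other side, the read is an at least 1.9-fold higher number from compound 2 to compound 3 (0.28 log units; that floor lies within the scatter), so compound 3 cannot be firmly set apart from compound 2 either, and a six-membered aromatic ring of carbon only cannot be tied to a change in clearance from these compounds. Compound 2 gives a limit and not a number, so the full size of its step to compound 3 stays unknown: the limit of < 14 mL.min-1.g-1 in this assay, at which 1 of the 3 values shown sits.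

Still open, as far as these compounds go, is whether the five-membered non-aromatic ring of compound 2 matters for clearance, or whether the step from compound 1 to compound 2 comes from some other difference between the two groups. A plain phenyl group at this aromatic carbon, or a methyl group on the indazole ring nitrogen, would help to separate the contribution of each ring, and a number for compound 2 in place of its limit would settle how far it stands from compound 3.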